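A few compounds are considered here, and "the series" means these few. Any claim that something is new, unique, unknown or untested is made for them only; others in the source may bear on it.

Of the compounds shown here, two sharing one core have been measured so far. Compound 1 `CCCCCCCCOC(=O)CCC(=O)N1CCN(CCCOc2cc3c(Nc4ccc(F)c(Cl)c4)ncnc3cc2OC)CC1` is tested in a functional assay on A549 cells (Homo sapiens) for cytotoxicity, read by MTT assay, with a stated time of 24 h, tested at 80 uM (on this read-out lower numbers stand for a stronger effect and higher numbers for a weaker effect at the one concentration tested), where compound 1 gives 21.7%. Compound 2 `CCCCCCCCCCCOC(=O)CCC(=O)N1CCN(CCCOc2cc3c(Nc4ccc(F)c(Cl)c4)ncnc3cc2OC)CC1` differs from it by propyl in place of hydrogen on a saturated chain carbon, eight bonds along the chain from an oxygen next to a carbonyl group, and in this assay compound 2 gives 2.8%. Within the data shown here, that single measured step, a number 18.9 percentage points lower from compound 1 to compound 2 (beyond the scatter), leaves compound 2 as the lowest of the two numbers known, with compound 1 the nearest to it.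

Compound 3 `CCCCCCCCCCCCCCCCCOC(=O)CCC(=O)N1CCN(CCCOc2cc3c(Nc4ccc(F)c(Cl)c4)ncnc3cc2OC)CC1` has not yet been measured. Its change from compound 2 is hexyl in place of hydrogen on a saturated chain carbon, ten or more bonds along the chain from an oxygen next to a carbonyl group. Among the measured compounds shown here, the only measured step that bears on this kind of lengthening is the one from compound 1 to compound 2, which lowered the read-out modestly and beyond the scatter. The same direction is expected here, but compound 2 already stands close to the bottom of the scale, so little room is left for a further fall. Compound 3 is therefore expected to give about 2% in this assay, with a range from 0% to 12%. The expected step, a number 0.8 percentage points lower from compound 2 to compound 3 (within the scatter), should stay within the scatter.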

Compound 3, a percentage reported as activity, at one concentration (the size of the read-out at that concentration, not a potency): 83.2%
Compound 3: the middle estimate sits 81.2 percentage points below what was measured; the whole stated range lies below it.
By their numbers in this assay, from the lowest: compound 2; then compound 1; then compound 3.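

In this assay, lengthening this ester chain does not push the read-out in one direction: hexyl in place of hydrogen on a saturated chain carbon, ten or more bonds along the chain from an oxygen next to a carbonyl group, gives a number 80.4 percentage points higher from compound 2 to compound 3 (beyond the scatter), which reverses the earlier change of a number 18.9 percentage points lower from compound 1 to compound 2 (beyond the scatter). Compound 3 also ends up on the far side of the shortest chain shown, since the same comparison with compound 1 gives a number 61.5 percentage points higher from compound 1 to compound 3 (beyond the scatter), so the effect of chain length here rises and then collapses rather than merely levelling off. Nothing available explains this reversal at the far end of the chain.

Three chain lengths cannot show where between compound 2 and compound 3 the turn lies, or whether it is gradual or sudden, which a chain of intermediate length could help to settle. From the compounds shown here alone, it also stays open whether a chain of similar length carrying an amine or a carboxylic acid would follow the same course.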